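Swapping a Hydroxy for an Isopropyl on the Side Chain

The source may report more compounds than this note shows. Statements on the series, on what has been measured and on what is new or still open speak of the compounds shown alone.

Measured compounds:
Compound 1, `NC(=O)CC[C@H](NC(=O)CN(c1ncnc2c1ncn2C1CCCCO1)C1CC1)C(=O)OCc1ccccc1`, in a functional assay on the whole organism (Tail, strain ICR) with Mus musculus as the target, in the tail flick test, with a stated time of 60 min, at a dose of 25 umol/kg by the oral route (a lower number here means a weaker effect, a higher number a stronger effect of the compound at the dose given), gives 39.4%.
Compound 2, `O=C(CN(c1nc(Cl)nc2[nH]cnc12)C1CC1)N[C@@H](CO)C(=O)O`, gives 39.8%.
Compound 3, `O=C(CN(c1ncnc2c1ncn2C1CCCCO1)C1CC1)N[C@@H](CO)C(=O)OCc1ccccc1`, gives 46.7%.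

Compound 3 has the highest of the three numbers, yet compound 2 and compound 1 both lie within the usual scatter of it, so the three compounds cannot be ranked against each other.

Compound 4, `CC(C)C[C@H](NC(=O)CN(c1ncnc2c1ncn2C1CCCCO1)C1CC1)C(=O)OCc1ccccc1`, differs from compound 3 in one place: isopropyl in place of hydroxy on a saturated chain carbon, two bonds along the chain from an amide-type nitrogen and a carbonyl carbon. Within the data shown here, only one measured step touches this spot. It is a number 7.3 percentage points higher from compound 1 to compound 3 (within the scatter), a step that stayed within the scatter even though the group on that saturated chain carbon changed considerably. Among the measured compounds shown here, no measured pair shows an isopropyl entering at this position, so there is nothing beyond that single step to lean on.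

Given that the one comparable exchange at the same carbon left this assay unchanged beyond the scatter, the expected step of a number 2.7 percentage points lower from compound 3 to compound 4 (within the scatter) is likewise small and without a clear direction. Compound 4 is therefore estimated at 44%, with a range from 30% to 58%.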

Compound 4, a percentage reported as activity, at one dose (the size of the read-out at that dose, not a potency): 34.2%
Compound 4: middle estimate off by 9.8 percentage points, on the high side, and the stated range covers the measured number.
By their numbers in this assay, from the lowest: compounds 4, 1, 2 and 3 (each within the scatter of the next, the first and the last beyond it).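

In this assay, among these compounds, the saturated chain carbon now shows that the group it carries can matter: a number 12.5 percentage points lower from compound 3 to compound 4 (beyond the scatter) is the first step at this position to lie beyond the scatter, with hydroxy leaving and isopropyl entering. The other new step, a number 5.2 percentage points lower from compound 1 to compound 4 (within the scatter), stays within the scatter, as does a number 7.3 percentage points higher from compound 1 to compound 3 (within the scatter), so carbamoylmethyl cannot be told apart from either hydroxy or isopropyl, and only the two ends of this short series, compound 3 and compound 4, separate. Nothing on hand explains why exchanging hydroxy for isopropyl at this carbon lowers the number in this assay.

The compounds shown leave open whether the drop follows the loss of the hydroxy or the arrival of the isopropyl, and a methyl or a plain hydrogen on this carbon would help to pull those two apart. They also leave open how an amine, a carboxylic acid or a longer chain of carbons at the same place would compare with hydroxy and isopropyl in this whole-animal test.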